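Methyl for Hydrogen on the Anilide Ring

A few compounds are considered here, and "the series" means these few. Any claim that something is new, unique, unknown or untested is made for them only; others in the source may bear on it.

Compound 1 `COc1ccc(-c2[nH]c3ccccc3c2C2=C(Br)C(=O)NC2=O)cc1`: 2.42
Compound 2 `CCCCCCc1ccc2[nH]c(-c3ccc(OC)cc3)c(C3=C(Br)C(=O)NC3=O)c2c1`: "not determined" (no result reported)
Compound 3 `O=C(CCCc1[nH]c2ccccc2c1C1=C(Br)C(=O)NC1=O)Nc1ccccc1`: 2.56

Three compounds share a core; two of them have a number in a physicochemical assay for lipophilicity; a lower number here means a more polar compound, a higher number a more lipophilic compound. In that assay compound 1 gives 2.42 and compound 3 gives 2.56. Compound 3 has the higher of the two numbers, but its gap to compound 1 lies within the scatter, so the two are indistinguishable on this evidence. For compound 2 this assay reports "not determined" (no result reported).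

Compound 4 `Cc1ccccc1NC(=O)CCCc1[nH]c2ccccc2c1C1=C(Br)C(=O)NC1=O` has not been measured. It differs from compound 3 in one place: methyl in place of hydrogen on an aromatic carbon. For the measured compounds named here, no pair of measured compounds shows this change, so its effect has to be anticipated rather than read off. A step of moderate size, upward, beyond the scatter, is what is expected; the estimated step from compound 3 to compound 4 is a number 0.44 log units higher from compound 3 to compound 4 (beyond the scatter). Compound 4 is accordingly expected to give about 3 in this assay, within a range from 2.7 to 3.4.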

Compound 4, partition coefficient: 2.56
For compound 4 the middle estimate is 0.44 log units above the measured one; measured number below the stated range.
By their numbers in this assay, from the lowest: compounds 1, 3 and 4 (each within the scatter of the next).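

In this assay, for the compounds shown here, the change from phenylcarbamoyl to (2-methylphenyl)carbamoyl gives no change at the digits printed from compound 3 to compound 4 (within the scatter) and so supplies the first step that can be read between two measured compounds. Going by these compounds alone, at this aromatic carbon, ortho to a large group, one added methyl therefore leaves the number where it stood, something the earlier compounds, which offered no such pair, could not show. Nothing in the data accounts for this result.

From the compounds shown here alone, whether a longer chain, an amine or a carboxylic acid at the same carbon would also leave the number in place remains open. So does whether a methyl on another carbon of this ring would behave as this one does, since a single pair speaks only for this one position.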